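This account rests on a few compounds, and the source may have more. Where it says the series, first, only, none or still open, it means among the compounds named here.

Among the two numbers so far, compound 2 `Cn1ccc2c(Oc3ccc(NC(=O)c4cc5cccnc5n(-c5ccccc5)c4=O)cc3)ccnc21` stands highest in a functional assay on HT-29 cells (Homo sapiens) for antiproliferative activity, read by MTT assay, with a stated time of 72 h; a higher number here means a weaker inhibitor, a lower number a stronger inhibitor: compound 2 gives 620 nM, whereas compound 1 `O=C(Nc1ccc(Oc2ccnc3[nH]ccc23)cc1)c1cc2cccnc2n(-c2ccc(F)cc2)c1=O` gives 160 nM, a gap beyond the usual scatter. Compound 3 `Cn1ccc2c(Oc3ccc(NC(=O)c4cc5cccnc5n(-c5ccc(F)cc5)c4=O)cc3)ccnc21` differs from compound 2 by fluoro in place of hydrogen on an aromatic carbon. Among the compounds with values here, no pair of measured compounds isolates this change. Because compound 1, which carries the same fluoro, gives 160 nM, a modest step toward a lower number is expected for compound 3, a 1.9-fold lower number from compound 2 to compound 3 (0.29 log units; within the scatter). Compound 3 is therefore estimated at 320 nM, within 120 nM to 850 nM.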

Compound 3, half-maximal inhibitory concentration: 250 nM
Beside the measured number, compound 3's estimate is 1.3-fold (0.11 log units) above it, within the range that was stated.
By their numbers in this assay, from the lowest: compounds 1 and 3 (each within the scatter of the next); then compound 2.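

In this assay, the change from phenyl to 4-fluorophenyl, on an aromatic carbon para to a large group, can now be read on its own, with a 2.5-fold lower number from compound 2 to compound 3 (0.39 log units; beyond the scatter) in the presence of the methyl on the aromatic nitrogen. Methyl in place of hydrogen on that nitrogen, with a 1.6-fold higher number from compound 1 to compound 3 (0.19 log units; within the scatter), separates the two 4-fluorophenyl compounds by no more than the scatter. Nothing here accounts for the fluoro step. Open, as far as these compounds go, is how another group at this place, such as chloro, methoxy or an amine, would compare with fluoro. Also open, from the compounds shown here alone, is whether the fluoro step holds with hydrogen on the aromatic nitrogen.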